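A few compounds are considered here, and "the series" means these few. Any claim that something is new, unique, unknown or untested is made for them only; others in the source may bear on it.

Measured so far:
compound 1, `CCc1ccc(NC(=S)N/N=C/c2cccs2)cc1`: > 100000 nM
compound 2, `S=C(N/N=C/c1cccs1)Nc1cccnc1`: 45900 nM
compound 3, `C=CCNC(=S)N/N=C/c1cccs1`: > 100000 nM

In a functional assay on NCI-H460 cells (Homo sapiens) for inhibition, read by sulforhodamine B assay, with a stated time of 48 h (on this read-out lower numbers stand for stronger inhibition of growth and higher numbers for weaker inhibition of growth), compound 1 gives only a limit, > 100000 nM, and so no number. Compound 3 likewise reaches only the limit of > 100000 nM in this assay. Among the compounds with values here, compound 2 is the single member with a numeric result, 45900 nM in this assay, and even that is weak. Where compound 1 stands is told by the limit of > 100000 nM in this assay, at which 2 of the 3 values shown sit: its inhibition of growth is too weak to be measured, as is that of compound 3, while compound 2 alone gives a number.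

Compound 4, `S=C(N/N=C/c1cccs1)Nc1ccc(Cl)cc1`, has not been measured in this assay. It differs from compound 1 in one place: chloro in place of ethyl on an aromatic carbon. No measured pair in this set traces a step of the same kind, so nothing shown tells how chloro in place of ethyl on an aromatic carbon shifts growth inhibition here. Compound 1 sits at the limit; only a move toward stronger inhibition could be seen at all. The step from compound 1 to compound 4 is expected to be small, an at least 1.2-fold lower number from compound 1 to compound 4 (0.09 log units; that floor lies within the scatter), and with fair probability compound 4 will again stop at the limit. Compound 4 is estimated at 80000 nM, between 30000 nM and 150000 nM.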

Compound 4, concentration for 50% growth inhibition: > 100000 nM
Compound 4: a limit, no number; the forecaster's own chance of this, stated with the estimate: 55%; middle value at least 1.2-fold (0.09 log units) away from the limit.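

Within the data shown here, with compound 4 as with compound 1, this assay gives only a limit and no number, so no step from compound 1 to compound 4 can be read. The compounds shown leave open whether chloro in place of ethyl on an aromatic carbon shifts growth inhibition at all, in either direction.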